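Adding a nitro group to compound 2

This account rests on a few compounds, and the source may have more. Where it says the series, first, only, none or still open, it means among the compounds named here.

Measured in a functional assay on Bel-7402 cells (Homo sapiens) for cytotoxicity, read by MTT assay, with a stated time of 48 h; a lower number here means a stronger inhibitor, a higher number a weaker inhibitor:
- compound 1 `CCn1cc(-c2nc3ccccc3o2)c(=O)c2cc(F)c(N3CCNC(C)C3)c(F)c21`: 5700 nM
- compound 2 `CCn1cc(-c2nc3ccccc3s2)c(=O)c2cc(F)c(N3CCNC(C)C3)c(F)c21`: 15000 nM

Of the two measured compounds, compound 2 stands highest at 15000 nM. Compound 3 `CCn1cc(-c2nc3ccc([N+](=O)[O-])cc3s2)c(=O)c2cc(F)c(N3CCNC(C)C3)c(F)c21` keeps the structure of compound 2 but has nitro in place of hydrogen on an aromatic carbon of the six-membered aromatic ring of carbon only: nitro in place of hydrogen on an aromatic carbon. For the measured compounds named here, no measured compound carries a nitro group, so the only measured step bears on this change indirectly. That step is modest, with 1,3-benzothiazol-2-yl in place of 1,3-benzoxazol-2-yl: a 2.6-fold higher number from compound 1 to compound 2 (0.42 log units; beyond the scatter). Going by that size, a modest step is expected in this assay, tentatively toward a lower number, since the data do not fix its direction. In this assay the estimate for compound 3 is 8000 nM, with an expected range from 2500 nM to 25000 nM. This estimate means an expected 1.9-fold lower number from compound 2 to compound 3 (0.27 log units; within the scatter).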

Compound 3, half-maximal inhibitory concentration: 4100 nM
Estimate against measurement, compound 3: 2.0-fold (0.29 log units) above; low and high end bracket the measured number.
By their numbers in this assay, from the lowest: compounds 3 and 1 (each within the scatter of the next); then compound 2.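

In this assay, for the compounds shown here, the nitro group gives the first measured change on the six-membered aromatic ring of carbon only, with (a 3.7-fold lower number from compound 2 to compound 3 (0.56 log units; beyond the scatter)). The earlier step had exchanged 1,3-benzoxazol-2-yl for 1,3-benzothiazol-2-yl, whereas this one shows that a substituent on this carbon, meta to a fused ring and para to a fused ring, is tolerated and moves the number lower by more than the scatter. Nothing available accounts for this step.

From the compounds shown here alone, it remains open whether an amine or a methoxy group on this same carbon would move the number the same way, so the step cannot yet be tied to nitro specifically. Also open, going by these compounds, is whether nitro on another carbon of this ring, or on the 1,3-benzoxazol-2-yl group of compound 1, would give a step of similar size.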